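Chain extension on the amine of the shared core

A few compounds are considered here, and "the series" means these few. Any claim that something is new, unique, unknown or untested is made for them only; others in the source may bear on it.

Measured so far in a functional assay for antagonist activity at 5-hydroxytryptamine receptor 4 (Rattus norvegicus); on this read-out lower numbers stand for lower potency and higher numbers for higher potency (the scale is a negative logarithm):
- compound 1 `COc1cc(COc2cc(N)c(Cl)cc2C(=O)CCCCN2CCC(O)CC2)cc(OC)c1`: 8.3
- compound 2 `CCCCN1CCC(CCC(=O)c2cc(Cl)c(N)cc2OCc2cc(OC)cc(OC)c2)CC1`: 8.9

Compound 2 stands highest of the two numbers; the nearest is compound 1, with a step of a number 0.60 log units higher from compound 1 to compound 2 (beyond the scatter).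

Compound 3 `CCCCCN1CCC(CCC(=O)c2cc(Cl)c(N)cc2OCc2cc(OC)cc(OC)c2)CC1` differs from compound 2 by methyl in place of hydrogen on a saturated chain carbon, four bonds along the chain from an amine nitrogen in a ring. Among the compounds with values here, no measured step touches this position: the step from compound 1 to compound 2 exchanges the whole amine-bearing chain, not the alkyl on the ring nitrogen, so it gives no direct guide. With nothing pointing either way, the expected step of no change at the digits printed from compound 2 to compound 3 (within the scatter) is taken as none beyond the scatter. Compound 3 is therefore estimated at 8.9, within 8.4 to 9.4.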

Compound 3, negative logarithm of the antagonist equilibrium constant: 9.1
For compound 3 the middle estimate is 0.20 log units below the measured one; measured number inside the range.
By their numbers in this assay, from the lowest: compound 1; then compounds 2 and 3 (each within the scatter of the next).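

In this assay, methyl in place of hydrogen on a saturated chain carbon, four bonds along the chain from an amine nitrogen in a ring, gives a number 0.20 log units higher from compound 2 to compound 3 (within the scatter), so this extension of the chain leaves the read-out unchanged within the scatter. The exchange of the whole side chain for 1-pentylpiperidin-4-yl gives a number 0.80 log units higher from compound 1 to compound 3 (beyond the scatter), which stays beyond the scatter, as it does with 1-butylpiperidin-4-yl. No available evidence bears on this result.

Still open, as far as these compounds go, is whether a longer chain such as hexyl, or a chain ending in a carboxylic acid, keeps the value of compound 3.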